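Series notes: methoxy to hydrogen on the outer ring

This account rests on a few compounds, and the source may have more. Where it says the series, first, only, none or still open, it means among the compounds named here.

Measured so far:
compound 1, `COc1ccc(-c2ccc(-c3ccc(C(=N)N)o3)o2)cc1`, 530 nM
compound 2, `N=C(N)c1ccc(-c2ccc(-c3ccc(Cl)cc3)s2)s1`, 1740 nM
compound 3, `COc1cc(OC)cc(-c2ccc(-c3ccc(C(=N)N)o3)o2)c1`, 1880 nM

In a functional assay on SW-620 cells (Homo sapiens) for inhibition, read by sulforhodamine B assay, with a stated time of 48 h (a higher number here means a weaker inhibitor of growth, a lower number a stronger inhibitor of growth), compound 1 gives 530 nM, the lowest of the three numbers. Compound 2 with 1740 nM and compound 3 with 1880 nM both sit beyond the scatter above it, so compound 1 is the strongest inhibitor of growth among the measured set. Compound 2 and compound 3 lie within the scatter of each other, and no ordering is claimed between them.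

Compound 4, `N=C(N)c1ccc(-c2ccc(-c3ccccc3)o2)o1`, is the next point. Relative to compound 1 the change is hydrogen in place of methoxy on an aromatic carbon. Within the data shown here, no measured pair in this set carries the same change, so the expected size of the step rests on the spread of the measured values alone. The methoxy-bearing compound 1 holds the best number, and its replacement by hydrogen is expected to cost little, with a step from compound 1 to compound 4 of a 1.7-fold higher number from compound 1 to compound 4 (0.23 log units; within the scatter), that is a modest rise toward the values of compound 2 and compound 3, possibly staying within the scatter. Compound 4 is therefore estimated at 900 nM, with a range from 350 nM to 2500 nM.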

Compound 4, concentration for 50% growth inhibition: 1790 nM
Estimate against measurement, compound 4: 2.0-fold (0.30 log units) below; measured number inside the range.
By their numbers in this assay, from the lowest: compound 1; then compounds 2, 4 and 3 (each within the scatter of the next).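

Working from the first pair in the series that differs in one place, this assay shows that hydrogen in place of methoxy on an aromatic carbon, para to a large group, gives a 3.4-fold higher number from compound 1 to compound 4 (0.53 log units; beyond the scatter) with the rest of the structure unchanged. Among these compounds, the position is thus not indifferent to what it carries: with the shared core held constant, methoxy goes with stronger growth inhibition than hydrogen, a reading that the earlier compounds, with no such pair among them, could not give. Nothing at hand bears on the reason for this step.

Going by these compounds, whether the step depends on methoxy itself or would be matched by another group on the same carbon remains open, and an ethoxy group, a hydroxyl group, a fluorine atom or an amine in that place would help separate these possibilities. On these data alone, with a single pair carrying this change, it also remains open whether the same replacement would produce a step of similar size on a different core.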